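From hydroxymethyl to methoxymethyl in an inactive pair

The compounds below may be only part of what the source reports. "The series", "measured", "known", "first", "only" and "open" are said of these compounds alone.

In a functional assay on HeLa cells (Homo sapiens) for cytotoxicity, read by WST assay, with a stated time of 48 h (on this read-out lower numbers stand for stronger inhibition and higher numbers for weaker inhibition), compound 1 `COc1cc(C(c2ccc(O)c(OC)c2)[C@@H](C)[C@@H](C)CO)ccc1O` gives > 100000 nM, which is a limit of the assay and not a number. Its mirror image, compound 2 `COc1cc(C(c2ccc(O)c(OC)c2)[C@H](C)[C@H](C)CO)ccc1O`, gives > 100000 nM, again only a limit. Going by the values given here, the one measured step is a step that the two limits leave unreadable from compound 1 to compound 2, so it offers no size to carry forward. Compound 3 `COC[C@H](C)[C@@H](C)C(c1ccc(O)c(OC)c1)c1ccc(O)c(OC)c1` carries 1-(methoxymethyl)ethyl in place of 1-(hydroxymethyl)ethyl (1-(methoxymethyl)ethyl in place of 1-(hydroxymethyl)ethyl on a saturated chain carbon bound to two saturated chain carbons). The expected change is small, at most a slight move towards stronger inhibition in this assay, and is an at least 1.2-fold lower number from compound 2 to compound 3 (0.09 log units; that floor lies within the scatter). Compound 3 is estimated at 80000 nM, within an expected range from 25000 nM to 200000 nM.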

Compound 3, half-maximal inhibitory concentration: 77000 nM
Estimate against measurement, compound 3: 1.0-fold (0.02 log units) above; low and high end bracket the measured number.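

Going by these compounds alone, compound 3 gives 77000 nM in this assay, the first value in this set that is a number and not a limit. Methoxymethyl in place of hydroxymethyl therefore reads as an at least 1.2-fold lower number from compound 2 to compound 3 (0.11 log units; that floor lies within the scatter), and the same comparison from the other partner reads as an at least 1.2-fold lower number from compound 1 to compound 3 (0.11 log units; that floor lies within the scatter). Both steps are floors, so neither shows a real gain at this position, because the starting values are limits: the limit of > 100000 nM in this assay, at which 2 of the 3 values shown sit.

Going by these compounds, how an amine, a carboxylic acid or a longer chain such as ethoxymethyl would read in this assay remains open.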